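Propyl for phenyl on the chain of compound 1

The compounds below may be only part of what the source reports. "The series", "measured", "known", "first", "only" and "open" are said of these compounds alone.

Compound 1 `O=c1[nH]c2ccccc2cc1/C=N/Cc1ccccc1` carries a phenyl on a saturated chain carbon bound to a double-bonded nitrogen. In a functional assay, read by spectrophotometry, with a stated time of 30 min (on this read-out lower numbers stand for stronger inhibition and higher numbers for weaker inhibition), compound 1 gives "not active" (no number reported), so it has no number to stand on; it sits outside the measured range of the series. Two compounds with an aromatic ring directly on the double-bonded nitrogen do give numbers: compound 2 `Cc1ccc2[nH]c(=O)c(/C=N/c3ccccc3O)cc2c1` in this assay gives 26200 nM, and compound 3 `O=c1[nH]c2ccccc2cc1/C=N/c1ccc(O)cc1` in this assay gives 92100 nM. Neither shares a single point of difference with compound 1, so their values only show that the shared core reaches measurable but weak inhibition in this set.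

Compound 4 `CCCC/N=C/c1cc2ccccc2[nH]c1=O` differs from compound 1 by propyl in place of phenyl on a saturated chain carbon bound to a double-bonded nitrogen. Among the measured compounds shown here, no measured step exists for this change. Since compound 1 gives "not active" (no number reported), the expectation in this assay is a small step at most, with weak inhibition or no number the likely outcome, and no direction can be set beyond the scatter. Compound 4 is estimated at 90000 nM, expected within 25000 nM to 320000 nM, with a real chance that only a limit is reported.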

Compound 4, half-maximal inhibitory concentration: 439000 nM
Estimate against measurement, compound 4: 4.9-fold (0.69 log units) below; the measured number lies above the stated range.
By their numbers in this assay, from the lowest: compound 2; then compound 3; then compound 4.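

No step can be read from compound 1 to compound 4: in this assay compound 1 gives "not active" (no number reported) and compound 4 gives 439000 nM as its number. The compounds shown leave open how propyl and phenyl compare on a saturated chain carbon bound to a double-bonded nitrogen. No evidence bears on this result.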